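A few compounds are considered here, and "the series" means these few. Any claim that something is new, unique, unknown or untested is made for them only; others in the source may bear on it.

Working notes on the series in a toxicity assay on NIH3T3 cells (Mus musculus) for cytotoxicity, read by resazurin assay; a lower number here means that less compound is needed, a higher number that more compound is needed for the effect.

Compound 1 `COC(=O)c1ccc(NCc2cncn2Cc2ccc(-c3ccccc3)cc2)cc1-c1ccccc1` sits at a limit of the assay: in this assay compound 1 gives > 1000 nM. Compound 3 `COc1ccc(NCc2cncn2Cc2ccc(-c3ccccc3)cc2)cc1-c1ccccc1` carries methoxy in place of methoxycarbonyl on an aromatic carbon, and the step from compound 1 to compound 3 is a step that the two limits leave unreadable from compound 1 to compound 3. Compound 3 also sits at a limit: in this assay compound 3 gives > 1000 nM. Compound 2 `Nc1cc(-c2ccccc2)ccc1Cn1cncc1CNc1ccc(-c2nc3ccccc3s2)c(-c2ccccc2)c1`, which carries the 1,3-benzothiazol-2-yl group on a different core, sits at a limit as well: in this assay compound 2 gives > 1000 nM. Where compound 3 stands is thus only a limit, and the same holds for the other two values, as summed up by the limit of > 1000 nM in this assay, at which 3 of the 3 values shown sit.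

Compound 4 `c1ccc(-c2ccc(Cn3cncc3CNc3ccc(-c4nc5ccccc5s4)c(-c4ccccc4)c3)cc2)cc1` is the next member. Its difference from compound 3 is 1,3-benzothiazol-2-yl in place of methoxy on an aromatic carbon. Among the measured compounds shown here, no measured step covers this change; the single measured step, from compound 1 to compound 3, is unreadable because both of its ends sit at the limit (the limit of > 1000 nM in this assay, at which 3 of the 3 values shown sit). Compound 2 is the only measured carrier of the entering group and itself sits at a limit. For compound 4 the expected step is therefore a step that the limit leaves unreadable from compound 3 to compound 4, none beyond the scatter, with a limit the most likely report. Compound 4 is estimated at 3000 nM, within 800 nM to 20000 nM.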

Compound 4, half-maximal effective concentration: > 1000 nM
Compound 4 ended at the assay's limit; the forecaster's own chance of this, stated with the estimate: 80%; the middle value lies beyond the limit too.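

No new step can be read in this assay: compound 4 shares its limit with compound 1, compound 2 and compound 3, so every comparison with it stays unreadable: the limit of > 1000 nM in this assay, at which 4 of the 4 values shown sit.

The compounds shown leave open how far apart these four compounds lie in this assay, and which change, if any, would bring a value inside the limit.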